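Three Inactive Lactones and a Fourth Awaiting Measurement

The source may hold more compounds than are shown below. What is called first, only, known or untested is meant among the compounds shown, and "the series" means these compounds.

Compound 1 `CCC1(c2ccccc2)CC(=O)C(C2CC(c3ccc(-c4ccc(Br)cc4)cc3)Cc3ccccc32)=C(O)O1`: in a functional assay on A549 cells (Homo sapiens) for inhibition, with a stated time of 72 h (on this read-out lower numbers stand for stronger inhibition and higher numbers for weaker inhibition), compound 1 gives > 10000 nM, which is a limit of the assay and not a number.
Compound 2 `CCC1(c2ccccc2)CC(=O)C(C2CC(c3ccc(OCc4ccc(C(F)(F)F)cc4)cc3)Cc3ccccc32)=C(O)O1`: in this assay compound 2 gives > 10000 nM, again a limit.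
Compound 3 `CCCC1(CCc2ccccc2)CC(=O)C(C2CC(c3ccc(-c4ccc(Br)cc4)cc3)Cc3ccccc32)=C(O)O1`: in this assay compound 3 gives > 10000 nM, likewise a limit.

Compound 1 and compound 2 share one core and differ in a single place: (4-(trifluoromethyl)benzyl)oxy in place of 4-bromophenyl on an aromatic carbon. The step that the two limits leave unreadable from compound 1 to compound 2 cannot be sized, since both of its ends are limits. Compound 3 carries another core; the difference between the two cores of compound 1 and compound 3 is not broken down here.

Compound 4 `CCCC1(CCc2ccccc2)CC(=O)C(C2CC(c3ccc(OCc4ccc(C(F)(F)F)cc4)cc3)Cc3ccccc32)=C(O)O1` has not yet been measured. It stands to compound 3 exactly as compound 2 stands to compound 1, the same change made a second time: (4-(trifluoromethyl)benzyl)oxy in place of 4-bromophenyl on an aromatic carbon.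

Among the compounds with values here, every measured value so far sits at the same limit (the limit of > 10000 nM in this assay, at which 3 of the 3 values shown sit). In this assay compound 4 is therefore expected to remain at that limit as well, an expected step that the limit leaves unreadable from compound 3 to compound 4. That expectation rests on the limit of > 10000 nM in this assay, at which 3 of the 3 values shown sit, and on the step that the two limits leave unreadable from compound 1 to compound 2, which gave no readable movement for the same change. The estimate for compound 4 is 20000 nM, with an expected range from 8000 nM to 100000 nM.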

Compound 4, half-maximal inhibitory concentration: > 10000 nM
Compound 4: a limit, no number (the forecaster's own chance of this, stated with the estimate: 85%); the middle value does not contradict the limit.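

In this assay compound 4 gives > 10000 nM, which is a limit of the assay and not a number. Both ends of the step from compound 3 to compound 4 are limits, so no size can be read from it. The result adds one more entry to a shared ceiling: the limit of > 10000 nM in this assay, at which 4 of the 4 values shown sit. The compounds shown leave open whether the change of group alters inhibition on either core, and how far any of the four lies beyond that limit.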